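The source may report more compounds than this note shows. Statements on the series, on what has been measured and on what is new or still open speak of the compounds shown alone.

In an ADME assay on MRC5 cells (Homo sapiens) for inhibition, with a stated time of 72 h (on this read-out lower numbers stand for an effect already at smaller amounts and higher numbers for an effect only at larger amounts of compound), three compounds of a shared core have been measured. Compound 1 `COc1cccc(OC)c1C(=O)Nc1c[nH]nc1C(=O)NC1CC1` reaches only a limit of the assay, > 50000 nM. Compound 2 `COc1cccc(OC)c1C(=O)Nc1c[nH]nc1C(=O)NN1CCOCC1` likewise stops at a limit, > 50000 nM. Going by the values given here, compound 3 `COc1cccc(OC)c1C(=O)Nc1c[nH]nc1C(=O)NC1CCCCC1` is the single compound to give a number, 35000 nM, and the weight of the set is set by the limit of > 50000 nM in this assay, at which 2 of the 3 values shown sit. The two steps that lead to compound 3 are an at least 1.4-fold lower number from compound 1 to compound 3 (0.15 log units; that floor lies within the scatter) and an at least 1.4-fold lower number from compound 2 to compound 3 (0.15 log units; that floor lies within the scatter); both carry only a floor that sits inside the scatter, and both replace the whole group on the amide-type nitrogen rather than adding to it. Compound 4 `COc1cccc(OC)c1C(=O)Nc1c[nH]nc1C(=O)NC1CCC(C)CC1` keeps that nitrogen's cyclohexyl and adds to it: methyl in place of hydrogen on a saturated ring carbon. Among the compounds with values here, no measured step shows a methyl on a saturated ring carbon, so nothing beyond the scatter is expected in this assay; a shift of a 1.2-fold lower number from compound 3 to compound 4 (0.07 log units; within the scatter) is estimated. Compound 4 is therefore expected near 30000 nM, between 12000 nM and 70000 nM, with a fair chance that the assay again returns only a limit.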

Compound 4, half-maximal effective concentration: 45000 nM
Beside the measured number, compound 4's estimate is 1.5-fold (0.18 log units) below it; the range from low to high includes it.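

In this assay, going by these compounds alone, the first step that adds to the cyclohexyl rather than replacing it is a 1.3-fold higher number from compound 3 to compound 4 (0.11 log units; within the scatter), so a methyl on a saturated ring carbon, three ring bonds from the ring atom that bears a large group, gives no step beyond the scatter. The replacements of the whole group, an at least 1.1-fold lower number from compound 2 to compound 4 (0.04 log units; that floor lies within the scatter) and an at least 1.1-fold lower number from compound 1 to compound 4 (0.04 log units; that floor lies within the scatter), carry only floors inside the scatter and do not separate 4-methylcyclohexyl from morpholin-4-yl or cyclopropyl. The set therefore still offers little room for reading differences: the limit of > 50000 nM in this assay, at which 2 of the 4 values shown sit.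

From the compounds shown here alone, it remains open whether an amine, a hydroxyl or a carboxylic acid on that ring carbon would give a step beyond the scatter. Going by these compounds, a longer chain such as ethyl or butyl there, or a methyl on another carbon of the ring, is equally open.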